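Methyl in place of hydrogen on compound 2

The source may report more compounds than this note shows. Statements on the series, on what has been measured and on what is new or still open speak of the compounds shown alone.

Measured in an ADME assay on Huh-7 cells (Homo sapiens) for cytotoxicity, read by scintillation counting, with a stated time of 2 days; a lower number here means that less compound is tolerated, a higher number that more compound is tolerated:
- compound 1 `Cc1cn([C@H]2C[C@H](Br)[C@@H](CO)O2)c(=O)[nH]c1=O`: > 100 ug/mL
- compound 2 `O=c1ccn([C@@H]2O[C@H](CO)[C@@H](Br)[C@@H]2O)c(=O)[nH]1`: > 100 ug/mL

Both entries are limits of the assay and not numbers. Compound 2 stands at the limit of > 100 ug/mL in this assay, at which 2 of the 2 values shown sit. Compound 3 `Cc1cn([C@@H]2O[C@H](CO)[C@@H](Br)[C@@H]2O)c(=O)[nH]c1=O` is the next step from compound 2, with methyl in place of hydrogen on an aromatic carbon. Among the measured compounds shown here, no step between measured compounds is available to size this change. In this assay, no step beyond the scatter is expected, and no direction is favoured. This expectation rests on compound 2 and its limit of > 100 ug/mL. The expected step is a step that the limit leaves unreadable from compound 2 to compound 3. Compound 3 is estimated at 120 ug/mL, with an expected range of 60 ug/mL to 250 ug/mL. A report as a limit is expected to be the likeliest outcome.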

Compound 3, half-maximal cytotoxic concentration: > 100 ug/mL
Compound 3: no number, only a limit; the forecaster's own chance of this, stated with the estimate: 85%; the middle value is on the limit's open side.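

Neither the step from compound 2 to compound 3 nor the step from compound 1 to compound 3 can be read, as all three compounds share one limit: the limit of > 100 ug/mL in this assay, at which 3 of the 3 values shown sit.

The compounds shown leave open what the half-maximal cytotoxic concentration of each actually is, and whether methyl in place of hydrogen on an aromatic carbon shifts it.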